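The source may hold more compounds than are shown below. What is called first, only, known or untested is meant among the compounds shown, and "the series" means these compounds.

Of the compounds shown here, two of one shared core have so far been tested in a functional assay on the whole organism (strain albino) for inhibition, with Rattus norvegicus as the target, read by paw edema, with a stated time of 2 h, at a dose of 0.029 mmol/kg by the oral route; on this read-out lower numbers stand for less inhibition and higher numbers for more inhibition at the one dose given (going by the name of the read-out). Compound 1, with the structure `N#Cc1ccc(/N=c2\c(C#N)c3n(c(=O)n2-c2ccccc2)CCC3)cc1`, gives 28.1% in this assay. Compound 2, with the structure `N#CC1=C(NCCN)N(c2ccccc2)C(=O)N2CCCC12`, gives 27.3% in this assay. The number for compound 2 stands alongside that of compound 1, and the two lie within the scatter of repeated measurements, so they count as the same level of inhibition.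

Compound 3, with the structure `CCO/C=N/C1=C(C#N)C2CCCN2C(=O)N1c1ccccc1`, is not yet measured in this assay. It differs from compound 2 in one place: a group of 5 heavy atoms (3 carbon, 1 nitrogen, 1 oxygen; no ring) in place of a group of 4 heavy atoms (2 carbon, 2 nitrogen; no ring), on a double-bonded ring carbon. The group that leaves carries hydrogen-bond donors, while the group that enters carries none, yet the rest of the core stays the same.

Going by the values given here, no measured pair here shows how a change at this place moves the read-out, so there is little ground for expecting a large shift. The step from compound 2 to compound 3 in this assay is expected to be a number 2.3 percentage points lower from compound 2 to compound 3 (within the scatter), which is not beyond the scatter. Compound 3 is therefore estimated to give 25% in this assay, within a range from 10% to 40%.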

Compound 3, a percentage reported as inhibition, in the whole organism at one dose (the size of the read-out at that dose, not a potency): 9.12%
Beside the measured number, compound 3's estimate is 15.9 percentage points above it; the whole stated range lies above it.
By their numbers in this assay, from the lowest: compound 3; then compounds 2 and 1 (each within the scatter of the next).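

In this assay, going by these compounds alone, the group on the double-bonded ring carbon turns out to matter: putting the group of 5 heavy atoms (3 carbon, 1 nitrogen, 1 oxygen; no ring) in place of (2-aminoethyl)amino gives a number 18.2 percentage points lower from compound 2 to compound 3 (beyond the scatter), the first step that can be read at this position. By the counts for the two groups, the change takes the number of hydrogen-bond donors from 2 to 0 while the number of hydrogen-bond acceptors stays at 2, but the groups also differ in their atoms and in the double bond of the entering group, so this single pair cannot show which difference matters. Nothing measured here explains the loss of inhibition.

The compounds shown leave open whether the terminal amine of the (2-aminoethyl)amino group is what keeps the read-out at its higher level, a question that a (2-hydroxyethyl)amino group, with a hydroxyl in place of that amine, could address. They also leave open how a longer chain such as (3-aminopropyl)amino would fare at this position.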